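Halogen swap on two cores of one series

This account rests on a few compounds, and the source may have more. Where it says the series, first, only, none or still open, it means among the compounds named here.

Compound 1 `CC1=CS[C@@](O)(c2ccc(Cl)cc2)c2noc(=O)n21` and compound 2 `CC1=CS[C@@](O)(c2ccc(Br)cc2)c2noc(=O)n21` share a core bearing a hydroxyl; compound 3 `CCCOC1(c2ccc(Cl)cc2)SC=C(C)n2c1noc2=O` and compound 4 `CCCOC1(c2ccc(Br)cc2)SC=C(C)n2c1noc2=O` carry a propoxy instead. The difference between the two cores is not broken down here. In a functional assay (Cavia porcellus) with Rattus norvegicus as the target (a lower number here means that less compound is needed, a higher number that more compound is needed for the effect), compound 1 gives 800 nM, compound 2 gives 320 nM and compound 3 gives 890 nM. The step of a 2.5-fold lower number from compound 1 to compound 2 (0.40 log units; beyond the scatter) belongs to the change (bromo in place of chloro on an aromatic carbon). Compound 4 repeats this change on the other core, (bromo in place of chloro on an aromatic carbon), at a place described in the same words, so it is the same change. The step is expected to carry over to the second core, giving an estimated 2.3-fold lower number from compound 3 to compound 4 (0.37 log units; beyond the scatter) in this assay. Compound 4 is expected at 380 nM, with a range from 180 nM to 800 nM. Within the data shown here, this rests on a 2.5-fold lower number from compound 1 to compound 2 (0.40 log units; beyond the scatter) as the only measured instance of the change, a thin footing, so the range is kept wide.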

Compound 4, half-maximal effective concentration: 410 nM
Compound 4: the middle estimate sits 1.1-fold (0.03 log units) below what was measured; low and high end bracket the measured number.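

Bromo in place of chloro gives a 2.2-fold lower number from compound 3 to compound 4 (0.34 log units; beyond the scatter) in this assay. Set beside the step on the hydroxyl core, this step is of the same size: the same change on two cores in this assay, a 2.5-fold lower number (0.40 log units; beyond the scatter) from compound 1 to compound 2 and a 2.2-fold lower number (0.34 log units; beyond the scatter) from compound 3 to compound 4, 1.2-fold (0.06 log units) apart, within the scatter of two such steps So 4-chlorophenyl to 4-bromophenyl carries over between these two cores in this assay, but two pairs do not show that it would hold on other cores or in other assays, and they give no explanation for the step.

The compounds shown leave open whether an iodo or a nitrile on that aromatic carbon would continue the trend. They also leave open whether the step survives with an amine or a longer chain in place of the hydroxyl or propoxy.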